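Swapping the aryl substituent on a sulfonyl benzothiazole urea

The source may hold more compounds than are shown below. What is called first, only, known or untested is meant among the compounds shown, and "the series" means these compounds.

Measured compounds:
- compound 1, `CN1CCN(CCCS(=O)(=O)c2ccc3nc(NC(=O)NC(=O)c4cccc(-n5cccn5)c4Cl)sc3c2)CC1`: 8.8 nM
- compound 2, `CS(=O)(=O)c1ccc2sc(NC(=O)NC(=O)c3ccccc3Cl)nc2c1`: 4700 nM
- compound 3, `CN1CCC(S(=O)(=O)c2ccc3nc(NC(=O)NC(=O)c4cc5c(cc4Cl)CCN5C)sc3c2)CC1`: 7.2 nM

These three compounds share a core in which a urea links a sulfonyl-bearing benzothiazole to an aroyl group. In an assay on HEK293 cells for displacement of a labelled ligand from growth hormone secretagogue receptor type 1 (Homo sapiens), with a stated time of 60 min (on this read-out lower numbers stand for stronger inhibition and higher numbers for weaker inhibition), compound 1 gives 8.8 nM, which is the second highest of the three numbers. Compound 3, with a different aroyl group and a different amine on the sulfonyl chain, gives 7.2 nM, and the two numbers lie within the scatter of each other. Compound 2, which carries a plain 2-chlorophenyl and a methylsulfonyl group without a basic amine, gives 4700 nM, far beyond the scatter from compound 1; as compound 2 differs from compound 1 in two places, no single change can be picked out as the reason.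

Compound 4, `CN1CCN(CCCS(=O)(=O)c2ccc3nc(NC(=O)NC(=O)c4cc(N5CCCC5)ccc4Cl)sc3c2)CC1`, is not yet measured. It keeps the core, the sulfonyl chain and the methylpiperazine of compound 1 and changes only the aroyl group: 2-chloro-5-(pyrrolidin-1-yl)phenyl in place of 2-chloro-3-(1H-pyrazol-1-yl)phenyl on a carbonyl carbon. Since compounds 1 and 3 show that different substituted aroyl groups can give closely similar numbers, the step is expected to be small, with a slight drift toward a higher number at most, and likely within the scatter. On that basis the step from compound 1 to compound 4 in this assay is estimated as a 1.7-fold higher number from compound 1 to compound 4 (0.23 log units; within the scatter). Compound 4 is expected to give about 15 nM, within a range from 4 nM to 60 nM.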

Compound 4, half-maximal inhibitory concentration: 0.29 nM
The estimate for compound 4 lay 52-fold (1.71 log units) above the measured number, outside the stated range (below it).
By their numbers in this assay, from the lowest: compound 4; then compounds 3 and 1 (each within the scatter of the next); then compound 2.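

In this assay, with the core, the sulfonyl chain and the methylpiperazine held fixed, 2-chloro-5-(pyrrolidin-1-yl)phenyl in place of 2-chloro-3-(1H-pyrazol-1-yl)phenyl on a carbonyl carbon gives a 30-fold lower number from compound 1 to compound 4 (1.48 log units; beyond the scatter), so this one group alone accounts for a large step. Among these compounds, this is the first pair here that differs in only one place, and it shows what the earlier compounds could not: the aryl group on this carbonyl carbon can by itself move the number far beyond the scatter, even though the two groups match in heavy-atom count and neither has a hydrogen-bond donor or a net charge. No measurement shown here offers an explanation for the step.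

The two groups differ both in the ring they carry and in the number of its place on the phenyl ring, so the step cannot be divided between those two differences. A 2-chloro-5-(1H-pyrazol-1-yl)phenyl or 2-chloro-3-(pyrrolidin-1-yl)phenyl group would separate them, and a 2-chloro-5-(piperidin-1-yl)phenyl group would test a six-membered ring in place of the pyrrolidine.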